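The source may report more compounds than this note shows. Statements on the series, on what has been measured and on what is new or still open speak of the compounds shown alone.

Three compounds share a core built around a piperidine amide carrying a chlorophenyl group, and all three were tested in an assay on THP-1 cells for displacement of a labelled ligand from C-C chemokine receptor type 1 (Homo sapiens); a higher number here means a weaker inhibitor, a lower number a stronger inhibitor. Compound 1 `Cc1ccc(C(=O)N[C@@H](C(=O)N2CCC(c3ccc(Cl)cc3)CC2)C(C)C)cc1` gives 25 nM, the lowest of the three numbers. Compound 3 `CC[C@@H](C)[C@@H](NC(=O)CCc1ccccc1)C(=O)N1CCC(c2ccc(Cl)cc2)CC1` gives 66 nM, and compound 2 `CCCC(NC(=O)c1ccccc1C)C(=O)N1CCC(c2ccc(Cl)cc2)CC1` gives 152 nM; both of these gaps to compound 1 lie beyond the usual scatter, so compound 1 stands as the strongest inhibitor of this set.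

Compound 4 `Cc1cccc(CCC(=O)N[C@@H](C(=O)N2CCC(c3ccc(Cl)cc3)CC2)C(C)C)c1` has not yet been measured. It differs from compound 1 in one place: 2-(3-methylphenyl)ethyl in place of 4-methylphenyl on a carbonyl carbon. The group leaving is an aromatic ring bonded directly to the carbonyl carbon, while the group entering carries its aromatic ring on a two-carbon chain, and the methyl on that ring moves as well.

Among the measured compounds shown here, no measured pair shows exactly this change. Compound 3, which also carries its aromatic ring on a two-carbon chain, gives a weaker number than compound 1, but it also differs at the side chain, so that comparison is indirect. A modest weakening is expected for the step of a 1.8-fold higher number from compound 1 to compound 4 (0.26 log units; within the scatter), of a size that may or may not exceed the scatter. Compound 4 is therefore expected to give about 45 nM in this assay, within a range from 15 nM to 150 nM.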

Compound 4, half-maximal inhibitory concentration: 22 nM
Estimate against measurement, compound 4: 2.0-fold (0.31 log units) above; the range from low to high includes it.
By their numbers in this assay, from the lowest: compounds 4 and 1 (each within the scatter of the next); then compound 3; then compound 2.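

Putting 2-(3-methylphenyl)ethyl in place of 4-methylphenyl on a carbonyl carbon gives a 1.1-fold lower number from compound 1 to compound 4 (0.06 log units; within the scatter) in this assay, so the two compounds cannot be told apart in this assay. Among the compounds shown here, this is the first direct reading at this position: within the shared core, the aromatic ring can sit on a two-carbon chain instead of being bonded directly to the carbonyl carbon, with the methyl placed differently, and the inhibitor remains as strong as compound 1 within the scatter. Nothing shown explains why the two numbers are so alike.

The chain and the methyl position differ together in this single step, so the compounds shown cannot say what each does alone, or whether their separate effects would be large and offsetting. Also open, going by these compounds, is how this position responds to other groups on a carbonyl carbon, such as a longer chain ending in an unsubstituted phenyl ring, an amine or a carboxylic acid.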